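The source may hold more compounds than are shown below. What is called first, only, known or untested is meant among the compounds shown, and "the series" means these compounds.

Measured so far:
compound 1, `CC(C)CCn1nc(-c2cccs2)c(O)c(C2=NS(=O)(=O)c3cc(CS(C)(=O)=O)ccc3N2)c1=O` — 0.467 h
compound 2, `CS(=O)(=O)Nc1ccc2c(c1)S(=O)(=O)N=C(c1c(O)c(-c3ccc(Cl)s3)nn(CCC3CC3)c1=O)N2` — > 1 h
compound 3, `CC(C)CCn1nc(C2CCCCC2)c(O)c(C2=NS(=O)(=O)c3cc(NS(C)(=O)=O)ccc3N2)c1=O` — 0.117 h

In an in vitro ADME assay on microsomes from liver (Homo sapiens) for metabolic stability, tested at 5 uM (a lower number here means that the compound disappears faster, a higher number that the compound lasts longer), compound 3 gives 0.117 h, the lowest of the two numbers shown; compound 1 gives 0.467 h, a higher number that lies beyond the usual scatter. For compound 2 the value > 1 h is a limit of this assay, not a number, and it sits at the limit of > 1 h in this assay, at which 1 of the 3 values shown sits.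

Compound 4, `CC(C)CCc1nn(CCC(C)C)c(=O)c(C2=NS(=O)(=O)c3cc(NS(C)(=O)=O)ccc3N2)c1O`, differs from compound 3 in one place: isopentyl in place of cyclohexyl on an aromatic carbon. Among the compounds with values here, no measured pair shows this change, so the account rests on expectation alone. The step of a 1.3-fold higher number from compound 3 to compound 4 (0.11 log units; within the scatter) is expected to be small, within the scatter, in no firm direction. Compound 4 is therefore estimated at 0.15 h in this assay, between 0.06 h and 0.4 h.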

Compound 4, half-life: 0.167 h
Estimate against measurement, compound 4: 1.1-fold (0.05 log units) below, and the stated range covers the measured number.
By their numbers in this assay, from the lowest: compounds 3 and 4 (each within the scatter of the next); then compound 1. At a limit, above all of these: compound 2.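

In this assay, within the data shown here, isopentyl in place of cyclohexyl on the aromatic carbon next to the ring nitrogen gives a 1.4-fold higher number from compound 3 to compound 4 (0.15 log units; within the scatter) as the first reading of a change at this position. With the rest of the structure held constant, the open chain and the six-membered carbon ring therefore cannot be told apart in half-life. Nothing measured here offers a cause for this result. Going by these compounds, whether an amine or a carboxylic acid at this position would give a step beyond the scatter remains open. So does whether this result holds with a different group on the ring nitrogen.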